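Moving the fluorine on the pendant phenyl ring

The source may report more compounds than this note shows. Statements on the series, on what has been measured and on what is new or still open speak of the compounds shown alone.

Compound 3 `COc1cc2c(Oc3ccc(NC(=O)c4cc(-c5ccc(F)cc5)ccn4)cc3F)ccnc2cc1OCCCN1CCCC1` gives 430 nM in a functional assay on HT-29 cells (Homo sapiens) for cytotoxicity, read by MTT assay, with a stated time of 72 h (a higher number here means a weaker inhibitor, a lower number a stronger inhibitor), the highest of the three numbers recorded; compound 1 `COc1cc2c(Oc3ccc(NC(=O)c4cc(-c5ccccc5F)ccn4)cc3F)ccnc2cc1OCCCN1CCN(C)CC1` gives 220 nM, which sits within the scatter of compound 3, while compound 2 `COc1cc2c(Oc3ccc(NC(=O)c4cc(-c5ccccc5)ccn4)cc3F)ccnc2cc1OCCCN1CCCC1` gives 120 nM, beyond the scatter below it. Among the compounds with values here, the single measured step that touches this region is a 3.6-fold higher number from compound 2 to compound 3 (0.55 log units; beyond the scatter), a modest weakening when a fluorine is placed on the pendant phenyl ring.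

Compound 4 `COc1cc2c(Oc3ccc(NC(=O)c4cc(-c5ccccc5F)ccn4)cc3F)ccnc2cc1OCCCN1CCCC1` has not yet been measured. Its change from compound 3 is 2-fluorophenyl in place of 4-fluorophenyl on an aromatic carbon, so the same atoms are kept and only the position of the fluorine on that ring is shifted. Within the data shown here, no measured pair isolates this shift: compound 1 carries the 2-fluorophenyl group but also a different amine, so its value can only hint that 2-fluorophenyl is compatible with a number in the range of compound 1. Because compound 3 stands at 430 nM and compound 2 at 120 nM, the expectation is that compound 4 returns part of the way toward compound 2, a step of a 2.0-fold lower number from compound 3 to compound 4 (0.29 log units; within the scatter). Compound 4 is therefore expected to give about 220 nM in this assay, with a plausible range from 90 nM to 550 nM.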

Compound 4, half-maximal inhibitory concentration: 230 nM
Compound 4: middle estimate off by 1.0-fold (0.02 log units), on the low side; measured number inside the range.
By their numbers in this assay, from the lowest: compounds 2, 1, 4 and 3 (each within the scatter of the next, the first and the last beyond it).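

Shifting the fluorine from 4-fluorophenyl to 2-fluorophenyl gives, in this assay, a 1.9-fold lower number from compound 3 to compound 4 (0.27 log units; within the scatter), so this first direct read of the change in position does not separate the two placements on the ring. Fluoro in place of hydrogen now has two readings: the step printed for the 4-fluorophenyl group, a 3.6-fold higher number from compound 2 to compound 3 (0.55 log units; beyond the scatter), lies beyond the scatter, whereas the one for the 2-fluorophenyl group, a 1.9-fold higher number from compound 2 to compound 4 (0.28 log units; within the scatter), stays within it, so a fluorine on this phenyl ring is not separated from the unsubstituted compound at every placement. Within the data shown here, compound 4 also supplies the first single-place comparison of the amine, and pyrrolidin-1-yl in place of 4-methylpiperazin-1-yl gives a 1.0-fold higher number from compound 1 to compound 4 (0.02 log units; within the scatter), which shows no separation between the two amines when the 2-fluorophenyl group is present.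

The compounds shown offer no measured basis for explaining any of these numbers. Still open, going by these compounds, is how a 2-chlorophenyl or 2-methoxyphenyl group would read in place of 2-fluorophenyl, and how a morpholin-4-yl group would compare with the two amines on the same chain.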